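This account rests on a few compounds, and the source may have more. Where it says the series, first, only, none or still open, it means among the compounds named here.

Measured in an ADME assay on MT4 cells (Homo sapiens) for cytotoxicity, read by MTT assay, with a stated time of 96 h; a lower number here means that less compound is tolerated, a higher number that more compound is tolerated:

- Compound 1 `C/C(=N\O)c1ccc2[nH]c(-c3ccccc3)nc2c1`: "not determined" (no result reported).
- Compound 2 `C/C(=N\NC(N)=S)c1ccc2[nH]c(-c3ccccc3)nc2c1`: >= 100000 nM, a limit and not a number.
- Compound 3 `C/C(=N\NC(N)=S)c1ccc2c(c1)nc(-c1ccccc1)n2C1CCCCC1`: 20000 nM.

The starting point, compound 2, has no exact result, only (the limit of >= 100000 nM in this assay, at which 1 of the 3 values shown sits). Its true position could therefore lie well beyond the number shown.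

Compound 4 `C/C(=N\NC(N)=S)c1ccc2[nH]c(-c3ccoc3)nc2c1` has not yet been measured. It differs from compound 2 by one change, furan-3-yl in place of phenyl on an aromatic carbon, between two ring nitrogen atoms.

Among the compounds with values here, only one measured step offers any guide, an at least 5.0-fold lower number from compound 2 to compound 3 (0.69 log units; beyond the scatter). That change is cyclohexyl in place of hydrogen on an aromatic nitrogen, so it occurs at a different place and involves a different kind of group. It shows that this series can move in this assay, but it gives no direct measure of a swap at the phenyl position. Within the data shown here, no measured compound tests such a swap.

With so little evidence, no clear step beyond the scatter is expected, and any shift is more likely to be downward from the limit. A second result reported only as a limit is quite likely. The expected change is an at least 1.1-fold lower number from compound 2 to compound 4 (0.04 log units; that floor lies within the scatter). Compound 4 is estimated at 90000 nM, with an expected range from 30000 nM to 150000 nM.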

Compound 4, half-maximal cytotoxic concentration: 86000 nM
Compound 4: the middle estimate sits 1.0-fold (0.02 log units) above what was measured, and the stated range covers the measured number.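

In this assay, within the data shown here, a swap at the ring carbon between two ring nitrogen atoms can now be read for the first time: furan-3-yl in place of phenyl gives an at least 1.1-fold lower number from compound 2 to compound 4 (0.06 log units; that floor lies within the scatter). Going by these compounds, the earlier step changed only the aromatic nitrogen, and this one shows that the phenyl position can be changed as well, though its true size stays unknown, as compound 2 is only a limit and not a number: the limit of >= 100000 nM in this assay, at which 1 of the 4 values shown sits. Compound 4 gives 86000 nM, which is the first exact number among the compounds shown that keep the hydrogen on the aromatic nitrogen, and so gives later changes to this form of the core a fixed point of comparison.

On these data alone, what stays open is whether the oxygen atom of the furan, the smaller ring or neither goes with this result, as a single swap cannot separate them. As far as these compounds go, it is also open how a furan-2-yl or thiophen-3-yl ring, or a phenyl ring carrying an amine or a carboxylic acid, would behave at this position.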